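Adding a chloro group to compound 3

This account rests on a few compounds, and the source may have more. Where it says the series, first, only, none or still open, it means among the compounds named here.

In a functional assay on PC-3 cells (Homo sapiens) for inhibition, read by sulforhodamine B assay, with a stated time of 48 h (a higher number here means a weaker inhibitor of growth, a lower number a stronger inhibitor of growth), compound 3 `Cc1ccc(-c2c(CNC(C)(C)C)c(C(=O)O)nn2-c2ccccc2)cc1` gives > 688000 nM, which is a limit and not a number. Compound 2 `CC(C)(C)NCc1c(C(=O)O)nn(-c2ccccc2)c1-c1ccc(Cl)cc1` gives 145000 nM. Compound 1 `CCOC(=O)c1nn(-c2ccccc2)c(-c2ccc(C)cc2)c1CNC(C)(C)C` gives 59900 nM; > 585000 nM (2 entries). Compound 4 `Cc1ccc(-c2c(CNC(C)(C)C)c(C(=O)O)nn2-c2ccc(Cl)cc2)cc1` differs from compound 3 by one change, phenyl to 4-chlorophenyl: chloro in place of hydrogen on an aromatic carbon. Going by the values given here, the only measured step that bears on it is an at least 4.7-fold higher number from compound 2 to compound 3 (0.67 log units; beyond the scatter), with methyl in place of chloro on an aromatic carbon elsewhere in the molecule. Chloro goes with the lower number there, so a modestly lower number is expected for compound 4, though this is indirect evidence. The expected change is an at least 2.7-fold lower number from compound 3 to compound 4 (0.43 log units; beyond the scatter). For compound 4 the estimated value is 250000 nM, with an expected range from 70000 nM to 700000 nM.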

Compound 4, concentration for 50% growth inhibition: > 629000 nM
Compound 4 was reported as a limit; the forecaster's own chance of this, stated with the estimate: 40%; at least 2.5-fold (0.40 log units) between middle value and limit.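

In this assay, going by these compounds alone, compound 3 gives > 688000 nM, a limit, so no step to compound 4 can be read. Compound 4 gives > 629000 nM, also a limit. As far as these compounds go, whether chloro in place of hydrogen on this ring changes growth inhibition remains open.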